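A few compounds are considered here, and "the series" means these few. Any claim that something is new, unique, unknown or untested is made for them only; others in the source may bear on it.

Working notes on the series. Compound 1 `Cc1cc2ccccc2nc1-c1cn(CCC(F)(F)C(F)(F)C(F)(F)C(F)(F)C(F)(F)C(F)(F)C(F)(F)C(F)(F)F)nn1` and compound 3 `CCc1cc2ccccc2nc1-c1cn(CCC(F)(F)C(F)(F)C(F)(F)C(F)(F)C(F)(F)C(F)(F)C(F)(F)C(F)(F)F)nn1` share one core; compound 2 `CCCc1cc2ccccc2nc1-c1cn(-c2ccc(F)cc2)nn1` and compound 4 `CCCCc1cc2ccccc2nc1-c1cn(-c2ccc(F)cc2)nn1`, not yet measured, share another, and the difference between the two cores is not broken down here.

In a functional assay on COLO 205 cells (Homo sapiens) for cytotoxicity, read by MTT assay, with a stated time of 24 h (a lower number here means a stronger inhibitor, a higher number a weaker inhibitor), compound 1 gives 75.8 ug/mL. Compound 3 gives 95.2 ug/mL in this assay. The step of a 1.3-fold higher number from compound 1 to compound 3 (0.10 log units; within the scatter) accompanied (methyl in place of hydrogen on a saturated chain carbon bound to an aromatic carbon).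

For compound 2 only a limit is known: in this assay compound 2 gives > 100 ug/mL, which is a limit of the assay and not a number. This is the limit of > 100 ug/mL in this assay, at which 1 of the 3 values shown sits.

The change from compound 2 to compound 4 is methyl in place of hydrogen on a saturated chain carbon, three bonds along the chain from an aromatic carbon. It is the same kind of change as from compound 1 to compound 3, though the place differs: there on a saturated chain carbon bound to an aromatic carbon, here three bonds along the chain from an aromatic carbon.

Compound 4 is expected to shift by about a step that the limit leaves unreadable from compound 2 to compound 4. That expectation rests on the small step of a 1.3-fold higher number from compound 1 to compound 3 (0.10 log units; within the scatter). Compound 4 is therefore estimated at 120 ug/mL, between 60 ug/mL and 250 ug/mL, most likely reported again only as a limit.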

Compound 4, half-maximal inhibitory concentration: > 100 ug/mL
Compound 4: a limit, no number; the forecaster's own chance of this, stated with the estimate: 70%; the middle value does not contradict the limit.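

In this assay compound 4 gives > 100 ug/mL as a limit of the assay and not a number. Compound 2 also stands only at a limit, so no step can be read between compound 2 and compound 4: the limit of > 100 ug/mL in this assay, at which 2 of the 4 values shown sit.

Still open, on these data alone, is whether the change from propyl to butyl moves the value in this assay at all, and how far compound 2 and compound 4 lie from each other.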